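This account rests on a few compounds, and the source may have more. Where it says the series, first, only, none or still open, it means among the compounds named here.

Of the compounds shown here, three have been run in an assay on isolated protein for inhibition of thyroid hormone receptor alpha (Homo sapiens), read by fluorescence polarization (on this read-out lower numbers stand for stronger inhibition and higher numbers for weaker inhibition), and every value so far is a limit. Compound 1 `CN(Cc1cccc(F)c1)C(=O)CCCNC(=O)c1ccc(S(C)(=O)=O)c([N+](=O)[O-])c1` gives > 60000 nM, a limit of the assay. Compound 2 `CS(=O)(=O)c1ccc(C(=O)NCCC(=O)N2CCc3ccccc32)cc1[N+](=O)[O-]` likewise gives > 60000 nM, a limit. Compound 3 `CC1CCN(C(=O)CCCNC(=O)c2ccc(S(C)(=O)=O)c([N+](=O)[O-])c2)CC1` gives > 60000 nM, again a limit. Among the measured compounds shown here, the one matched step, a step that the two limits leave unreadable from compound 1 to compound 3, cannot be read because the limit of > 60000 nM in this assay, at which 3 of the 3 values shown sit, holds both of its ends. Compound 4 `CS(=O)(=O)c1ccc(C(=O)NCCCC(=O)N2Cc3ccccc3C2)cc1[N+](=O)[O-]` differs from compound 3 by a group of 9 heavy atoms (8 carbon, 1 nitrogen; one five-membered non-aromatic ring with 1 hetero atom, one six-membered aromatic ring of carbon only) in place of a group of 7 heavy atoms (6 carbon, 1 nitrogen; one six-membered non-aromatic ring with 1 hetero atom), on a carbonyl carbon. For the measured compounds named here, no measured step bears on this change, and no size can be read from the values to hand. With nothing in the series yet inside the readable range, compound 4 is expected to stay at the limit as well, the step that the limit leaves unreadable from compound 3 to compound 4 being an expectation rather than a reading. The estimate for compound 4 is 100000 nM, between 20000 nM and 500000 nM, with a high chance that only a limit is reported.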

Compound 4, half-maximal inhibitory concentration: > 60000 nM
Compound 4: a limit, no number; the forecaster's own chance of this, stated with the estimate: 85%; the middle value is on the limit's open side.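

Compound 4 gives > 60000 nM as a limit, and the steps to it from compound 3 and compound 1 cannot be read: the limit of > 60000 nM in this assay, at which 4 of the 4 values shown sit. The compounds shown leave open whether any group on the carbonyl carbon brings a value inside the readable range.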